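A Flat Series Meets a 2-Fluorophenyl Group

The compounds below may be only part of what the source reports. "The series", "measured", "known", "first", "only" and "open" are said of these compounds alone.

Measured in a functional assay on K562 cells (Homo sapiens) for cytotoxicity, read by MTT assay, with a stated time of 72 h; a higher number here means a weaker inhibitor, a lower number a stronger inhibitor:
- compound 1 `C=C1C(=O)[C@@]23C(=O)OC[C@]4(C(=O)CCC(C)(C)[C@H]4C=O)[C@@H]2CC[C@@H]1[C@H]3OC(=O)CC`: 1310 nM
- compound 2 `C=C1C(=O)[C@@]23C(=O)OC[C@]4(C(=O)CCC(C)(C)[C@H]4C=O)[C@@H]2CC[C@@H]1[C@H]3OC(=O)c1ccc(C)cc1`: 1270 nM
- compound 3 `C=C1C(=O)[C@@]23C(=O)OC[C@]4(C(=O)CCC(C)(C)[C@H]4C=O)[C@@H]2CC[C@@H]1[C@H]3OC(=O)c1ccc([N+](=O)[O-])cc1`: 1330 nM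

Compound 3 cannot be told apart from the other two compounds on these numbers. The data show a 1.0-fold higher number from compound 1 to compound 3 (0.01 log units; within the scatter) and a 1.0-fold higher number from compound 2 to compound 3 (0.02 log units; within the scatter), and both lie within the scatter.

The next compound, compound 4 `C=C1C(=O)[C@@]23C(=O)OC[C@]4(C(=O)CCC(C)(C)[C@H]4C=O)[C@@H]2CC[C@@H]1[C@H]3OC(=O)c1ccccc1F`, keeps the shared core and alters one group: 2-fluorophenyl in place of 4-nitrophenyl on a carbonyl carbon. This places 2-fluorophenyl in place of 4-nitrophenyl on a carbonyl carbon.

All three measured steps bear on this change. Ethyl gave way to 4-methylphenyl in a 1.0-fold lower number from compound 1 to compound 2 (0.01 log units; within the scatter), ethyl gave way to 4-nitrophenyl in a 1.0-fold higher number from compound 1 to compound 3 (0.01 log units; within the scatter), and nitro replaced methyl on an aromatic carbon in a 1.0-fold higher number from compound 2 to compound 3 (0.02 log units; within the scatter). None of these steps exceeds the scatter, so across compound 1, compound 2 and compound 3, changing this group has not visibly moved the number in this assay. Among the compounds with values here, no measured compound carries a 2-fluorophenyl group, however, so the new group itself remains untested.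

No step beyond the scatter is therefore expected, and the estimated step is a 1.0-fold lower number from compound 3 to compound 4 (0.01 log units; within the scatter). For compound 4 the expected value is 1300 nM, with an estimated range of 800 nM to 2100 nM.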

Compound 4, half-maximal inhibitory concentration: 2860 nM
Estimate against measurement, compound 4: 2.2-fold (0.34 log units) below, outside the stated range (above it).
By their numbers in this assay, from the lowest: compounds 2, 1 and 3 (each within the scatter of the next); then compound 4.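

Until compound 4, the group on this carbonyl carbon seemed to make no visible difference in this assay, with ethyl, 4-methylphenyl and 4-nitrophenyl all within the scatter of one another. The 2-fluorophenyl group breaks that flat picture, and the number rises beyond the scatter against each of the three earlier groups (a 2.2-fold higher number from compound 3 to compound 4 (0.33 log units; beyond the scatter); a 2.3-fold higher number from compound 2 to compound 4 (0.35 log units; beyond the scatter); a 2.2-fold higher number from compound 1 to compound 4 (0.34 log units; beyond the scatter)), though each step is modest. This position is therefore not indifferent to every group placed on it, even though the three earlier compounds gave no sign of this, and nothing measured here accounts for the step.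

The compounds shown do not separate the effect of the fluorine itself from that of where it sits on the aromatic ring, as 2-fluorophenyl differs from 4-methylphenyl and 4-nitrophenyl in both the atom carried and its place. Still open, from the compounds shown here alone, is how an unsubstituted phenyl group, a chlorine in place of the fluorine, or a chain ending in an amine on this carbonyl carbon would read in this assay.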